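Aryl piperazine thiosemicarbazone series: a chlorophenyl variant

The source may report more compounds than this note shows. Statements on the series, on what has been measured and on what is new or still open speak of the compounds shown alone.

The series shares one core, carried in compound 1 `O=C1Nc2ccc(Cl)cc2/C1=N/NC(=S)N1CCN(c2ccccc2)CC1` with a phenyl on the ring nitrogen. In a functional assay on MCF7 cells (Homo sapiens) for inhibition, read by MTT assay, with a stated time of 72 h (on this read-out lower numbers stand for stronger inhibition and higher numbers for weaker inhibition), compound 1 gives 10400 nM. Compound 2 `COc1ccc(N2CCN(C(=S)N/N=C3\C(=O)Nc4ccc(Cl)cc43)CC2)cc1` carries 4-methoxyphenyl there, and in this assay compound 2 gives 13800 nM. Compound 3 `Cc1ccc(N2CCN(C(=S)N/N=C3\C(=O)Nc4ccc(Cl)cc43)CC2)c(C)c1` carries 2,4-dimethylphenyl, and in this assay compound 3 gives 10800 nM. The steps of a 1.3-fold higher number from compound 1 to compound 2 (0.12 log units; within the scatter), a 1.0-fold higher number from compound 1 to compound 3 (0.02 log units; within the scatter) and a 1.3-fold lower number from compound 2 to compound 3 (0.11 log units; within the scatter) all lie within the scatter. Compound 3 thus stands as the second highest of the three numbers, yet none of the three is separated from another.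

Compound 4 `O=C1Nc2ccc(Cl)cc2/C1=N/NC(=S)N1CCN(c2ccccc2Cl)CC1` is not yet measured. Relative to compound 3 the change is 2-chlorophenyl in place of 2,4-dimethylphenyl on an amine nitrogen in a ring. The two steps that alter the group on that same ring nitrogen, a 1.0-fold higher number from compound 1 to compound 3 (0.02 log units; within the scatter) and a 1.3-fold lower number from compound 2 to compound 3 (0.11 log units; within the scatter), both stayed within the scatter, so varying this aryl group has so far left this assay unmoved. Among the compounds with values here, no measured step involves a chlorine on this group, so the data give no direction for it. The step from compound 3 to compound 4 is expected to be none beyond the scatter, a 1.0-fold higher number from compound 3 to compound 4 (0.01 log units; within the scatter). For compound 4 the estimated value is 11000 nM, with a range from 5500 nM to 22000 nM.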

Compound 4, half-maximal inhibitory concentration: 11700 nM
Beside the measured number, compound 4's estimate is 1.1-fold (0.03 log units) below it; the measured number falls inside the stated range.
By their numbers in this assay, from the lowest: compounds 1, 3, 4 and 2 (each within the scatter of the next).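

In this assay, chlorine on the aryl group at this ring nitrogen gives no separation from the earlier groups: a 1.1-fold higher number from compound 1 to compound 4 (0.05 log units; within the scatter) and a 1.1-fold higher number from compound 3 to compound 4 (0.03 log units; within the scatter) and a 1.2-fold lower number from compound 2 to compound 4 (0.07 log units; within the scatter) all lie within the scatter. Phenyl, 4-methoxyphenyl, 2,4-dimethylphenyl and 2-chlorophenyl therefore cannot be told apart in this assay, and none of compounds 1 to 4 goes against that reading, so exchanging the all-carbon methyl substituents of 2,4-dimethylphenyl for the chlorine of 2-chlorophenyl leaves the read-out where it was. No supporting measurement is available to account for this flat behaviour.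

On these data alone, all four compounds carry a phenyl ring on this nitrogen, so it remains open whether a group of another kind there, such as a carboxylic acid on the ring, an aminoethyl chain or a longer alkyl chain in place of the ring, would produce a step beyond the scatter. It also remains open how much the shared core contributes to the common level of these numbers, since that core does not vary among the compounds shown.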